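The compounds below may be only part of what the source reports. "The series", "measured", "known", "first", "only" and "open" are said of these compounds alone.

Of the compounds shown here, three sharing one core have been measured in an assay on HEK293 cells for binding affinity to Gonadotropin-releasing hormone receptor (Homo sapiens), read by radioligand binding; on this read-out lower numbers stand for stronger inhibition and higher numbers for weaker inhibition. Compound 1 `COc1cccc(-c2c(C)n(Cc3c(F)cccc3F)c(=O)n(C[C@@H](N)C(C)C)c2=O)c1F` gives 973 nM. Compound 2 `COc1cccc(-c2c(C)n(Cc3c(F)cccc3F)c(=O)n(C[C@@H](N)C3CCCC3)c2=O)c1F` gives 94 nM. Compound 3 `COc1cccc(-c2c(C)n(Cc3c(F)cccc3F)c(=O)n(C[C@@H](N)C3CCCCC3)c2=O)c1F` gives 46 nM, the lowest of the three numbers, with compound 2 nearest and compound 1 furthest away. The step of a 2.0-fold lower number from compound 2 to compound 3 (0.31 log units; beyond the scatter) is modest, so the two ring-bearing compounds sit close together, whereas the open isopropyl of compound 1 stands well apart.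

Compound 4 `COc1cccc(-c2c(C)n(Cc3c(F)cccc3F)c(=O)n(C[C@H](N)CC(C)C)c2=O)c1F` has not yet been measured. It differs from compound 3 in one place: 1-amino-3-methylbutyl in place of amino(cyclohexyl)methyl on a saturated chain carbon bound to an aromatic nitrogen. The entering group is a chain without a ring, and the measured steps that bear on such a change are a 21-fold lower number from compound 1 to compound 3 (1.33 log units; beyond the scatter) and a 10-fold lower number from compound 1 to compound 2 (1.01 log units; beyond the scatter), both large, each showing that moving from a ring to a branched chain at this position goes along with a much higher number. A chain of five carbon atoms is not identical to isopropyl, so the step need not be as large, but a clearly higher number than that of compound 3 is expected.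

Compound 4 is therefore expected to show a step of a 7.6-fold higher number from compound 3 to compound 4 (0.88 log units; beyond the scatter). For compound 4 the estimate is 350 nM, within a range from 120 nM to 1200 nM.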

Compound 4, inhibition constant: 6.4 nM
Compound 4: the middle estimate sits 55-fold (1.74 log units) above what was measured, and the stated range ends above it.
By their numbers in this assay, from the lowest: compound 4; then compound 3; then compound 2; then compound 1.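

In this assay, among these compounds, replacing amino(cyclohexyl)methyl with the open chain 1-amino-3-methylbutyl gives the lowest number so far (a 7.2-fold lower number from compound 3 to compound 4 (0.86 log units; beyond the scatter)), and the same chain also outdoes amino(cyclopentyl)methyl (a 15-fold lower number from compound 2 to compound 4 (1.17 log units; beyond the scatter)), so a ring is not needed here for a low number. The widest gap separates two groups that both lack a ring (a 150-fold lower number from compound 1 to compound 4 (2.18 log units; beyond the scatter)), which means that the high number of compound 1 cannot be put down simply to its having no ring, and that the difference between 1-amino-2-methylpropyl and 1-amino-3-methylbutyl matters greatly at this place, on a saturated chain carbon bound to an aromatic nitrogen. No independent measurement is available to explain why these chains differ so sharply.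

The compounds shown leave open whether a still longer chain, such as 1-amino-4-methylpentyl, would lower the number further or raise it again. They also leave open whether a benzene ring set further out along the chain, as in 1-amino-2-phenylethyl, would behave like the open chain or like the rings directly attached in compound 2 and compound 3.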